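Cyclopropyl in place of ethyl on an aromatic nitrogen

The source may hold more compounds than are shown below. What is called first, only, known or untested is meant among the compounds shown, and "the series" means these compounds.

In a functional assay on HL-60 cells (Homo sapiens) for antiproliferative activity, read by MTT assay, with a stated time of 72 h (a higher number here means a weaker inhibitor, a lower number a stronger inhibitor), compound 1 `N=C(NS(=O)(=O)c1ccccc1)N1CCN(c2cc3c(cc2F)c(=O)c(C(=O)O)cn3C2CC2)CC1` gives 43 nM and compound 2 `Cc1ccc(S(=O)(=O)NC(=N)N2CCN(c3cc4c(cc3F)c(=O)c(C(=O)O)cn4C3CC3)CC2)cc1` gives 43 nM as well. Compound 3 `CCn1cc(C(=O)O)c(=O)c2cc(F)c(N3CCN(C(=N)NS(=O)(=O)c4ccccc4Cl)CC3)cc21` also gives 43 nM in this assay and so stands level with both. Compound 4 `N=C(NS(=O)(=O)c1ccccc1Cl)N1CCN(c2cc3c(cc2F)c(=O)c(C(=O)O)cn3C2CC2)CC1` differs from compound 3 in one place cyclopropyl in place of ethyl on an aromatic nitrogen with cyclopropyl in place of ethyl on an aromatic nitrogen. Going by the values given here, no measured step tests this swap, and the only one available shows no change at the digits printed from compound 1 to compound 2 (within the scatter) for a different change, methyl in place of hydrogen on an aromatic carbon. All three values sit together, so no step beyond the scatter is expected in this assay here. The estimated step is no change at the digits printed from compound 3 to compound 4 (within the scatter) with no direction favoured. In this assay compound 4 is estimated at 43 nM with 18 nM to 100 nM as the expected range.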

Compound 4, half-maximal inhibitory concentration: 43 nM
Estimate against measurement, compound 4: no gap at the digits printed, within the range that was stated.
By their numbers in this assay, from the lowest: compounds 1, 2, 3 and 4 (each within the scatter of the next).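

In this assay, cyclopropyl in place of ethyl on the aromatic nitrogen gives no change at the digits printed from compound 3 to compound 4 (within the scatter), the first measured test of this swap at this position. The sulfonyl side behaves alike: 2-chlorophenyl in place of 4-methylphenyl on the sulfonyl sulfur gives no change at the digits printed from compound 2 to compound 4 (within the scatter), and replacing a hydrogen with a chloro group gives no change at the digits printed from compound 1 to compound 4 (within the scatter). Nothing measured here offers a reason for these results.

Still open, going by these compounds, is whether a phenyl or an n-propyl chain on that nitrogen would keep this value. So is the effect of an amide in place of the carboxy group.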